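The compounds below may be only part of what the source reports. "The series", "measured", "known", "first", "only" and "open" are said of these compounds alone.

Measured compounds:
- compound 1 `O=C1C=C(Nc2ccc(I)cc2)C(=O)c2c1nc1n2[C@H]2OC[C@@H](O)[C@H]2OC1`: 2230 nM
- compound 2 `Cc1ccc(NC2=CC(=O)c3nc4n(c3C2=O)[C@H]2OC[C@@H](O)[C@H]2OC4)cc1C`: 2080 nM
- compound 3 `CCCc1ccc(NC2=CC(=O)c3c(nc4n3[C@H]3OC[C@@H](O)[C@H]3OC4)C2=O)cc1`: > 4000 nM

In a functional assay on MCF7 cells (Homo sapiens) for inhibition, read by sulforhodamine B assay (on this read-out lower numbers stand for stronger inhibition and higher numbers for weaker inhibition), compound 1 gives 2230 nM and compound 2 gives 2080 nM. For the measured compounds named here, the single measured step, a 1.1-fold lower number from compound 1 to compound 2 (0.03 log units; within the scatter), swaps one substituted phenyl for another and leaves the read-out essentially where it was. For compound 3, this assay reports only a limit, > 4000 nM, so no exact number is known for it. Of the three values shown, compound 3 is the one sitting at the limit of > 4000 nM in this assay, at which 1 of the 3 values shown sits.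

Compound 4 `O=C1C(NC2CC2)=CC(=O)c2c1nc1n2[C@H]2OC[C@@H](O)[C@H]2OC1` has not yet been measured. It differs from compound 3 in one place: cyclopropyl in place of 4-propylphenyl on an amine nitrogen. Going by the values given here, no measured step covers a change of this kind. The step from an iodophenyl to a dimethylphenyl, a 1.1-fold lower number from compound 1 to compound 2 (0.03 log units; within the scatter), compares two aromatic groups and says nothing about a small non-aromatic ring taking their place. The two aromatic compounds with numbers, compound 1 and compound 2, lie within the scatter of each other, while compound 3 is known only as a limit, so the starting point itself is uncertain.

Compound 4 is therefore estimated at 4500 nM, with a range from 1500 nM to 15000 nM. The expected step is a step that the limit leaves unreadable from compound 3 to compound 4, and a limit rather than a number would not be surprising.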

Compound 4, half-maximal inhibitory concentration: > 16000 nM
Compound 4 was reported as a limit; the forecaster's own chance of this, stated with the estimate: 55%; middle value at least 3.5-fold (0.55 log units) away from the limit.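

Compound 3 and compound 4 are both reported only as limits, so the step from 4-propylphenyl to cyclopropyl on the amine nitrogen cannot be read. The compounds shown leave open what exact number either compound would give in this assay, and whether this swap of rings changes the read-out at all.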